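The compounds below may be only part of what the source reports. "The series", "measured", "known", "first", "only" and "open" are said of these compounds alone.

Compound 3 `CC(C)(C)c1cc(NC(=O)[C@@H]2CCCCN2C(=O)N2CCOCC2)no1` is one of three compounds that share a core and differ only in the group on the ring amine nitrogen. In a physicochemical assay for solubility, read by HPLC, at pH 6.8 (a lower number here means a less soluble compound, a higher number a more soluble compound), compound 3 gives 45 ug/mL. Compound 2 `CC(C)(C)c1cc(NC(=O)[C@@H]2CCCCN2C(=O)N2CCCCC2)no1` gives 49 ug/mL in this assay, and the pair differ by a 1.1-fold lower number from compound 2 to compound 3 (0.04 log units; within the scatter), so compound 3 stands as the lower of the two numbers without any order between them being claimed. Compound 1 `CC(C)(C)c1cc(NC(=O)[C@@H]2CCCCN2Cc2ccc(Cl)cc2)no1` gives only a limit in this assay, < 0.1 ug/mL. Against that limit the two ureas stand far apart: an at least 490-fold higher number from compound 1 to compound 2 (2.69 log units; beyond the scatter) and an at least 450-fold higher number from compound 1 to compound 3 (2.65 log units; beyond the scatter).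

Compound 4 `CC(C)(C)c1cc(NC(=O)[C@@H]2CCCCN2C(=O)N2CC[S+]([O-])CC2)no1` differs from compound 3 in one place: a group of 7 heavy atoms (4 carbon, 1 nitrogen, 1 oxygen, 1 sulfur; one six-membered non-aromatic ring with 2 hetero atoms) in place of a group of 6 heavy atoms (4 carbon, 1 nitrogen, 1 oxygen; one six-membered non-aromatic ring with 2 hetero atoms), on a carbonyl carbon. Among the measured compounds shown here, no measured step exchanges one six-membered ring with two hetero atoms for another of the same kind in which sulfur replaces oxygen. The nearest guide is the exchange of piperidin-1-yl for morpholin-4-yl on the same carbonyl carbon, which gave a 1.1-fold lower number from compound 2 to compound 3 (0.04 log units; within the scatter), a step within the scatter. The large steps from compound 1 concern the loss of 4-chlorobenzyl and do not bear on this change. Compound 4 is therefore expected to give a number close to that of compound 3, a step of a 1.3-fold higher number from compound 3 to compound 4 (0.12 log units; within the scatter) at most. For compound 4 the estimate in this assay is 60 ug/mL, with a range from 25 ug/mL to 150 ug/mL.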

Compound 4, solubility: 68 ug/mL
Beside the measured number, compound 4's estimate is 1.1-fold (0.05 log units) below it; the range from low to high includes it.
By their numbers in this assay, from the lowest: compounds 3, 2 and 4 (each within the scatter of the next). At a limit, below all of these: compound 1.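

Exchanging morpholin-4-yl on a carbonyl carbon for the six-membered non-aromatic ring that holds sulfur and oxygen leaves the number in this assay within the scatter, with a 1.5-fold higher number from compound 3 to compound 4 (0.18 log units; within the scatter) and a 1.4-fold higher number from compound 2 to compound 4 (0.14 log units; within the scatter). Three different six-membered non-aromatic rings, each with no net charge, have now stood at this place, on a carbonyl carbon whose other neighbour is an amide-type nitrogen in a ring, and compound 2, compound 3 and compound 4 cannot be put in any order in this assay. All three stand far from the 4-chlorobenzyl compound, as shown by an at least 680-fold higher number from compound 1 to compound 4 (2.83 log units; beyond the scatter), but that step is measured against a limit and not a number: the limit of < 0.1 ug/mL in this assay, at which 1 of the 4 values shown sits.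

The compounds shown leave open whether an amine or a carboxylic acid on this ring, or an open alkyl chain in place of the ring, would move the number beyond the scatter. They also leave open which part of the exchange from 4-chlorobenzyl carries the large step, since a benzyl group without chlorine on that ring nitrogen is not among them.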